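The source may hold more compounds than are shown below. What is called first, only, known or untested is meant among the compounds shown, and "the series" means these compounds.

Working notes on the series. Of the compounds shown here, three have been measured in a functional assay on NCI-H1581 cells (Homo sapiens) for inhibition, read by MTT assay, with a stated time of 48 h, tested at 10 uM; a lower number here means less inhibition, a higher number more inhibition at the concentration tested (going by the name of the read-out). Compound 1 `CCc1ccc(Nc2cc(NC(=O)Nc3cc(OC)cc(OC)c3)ncn2)cc1` gives 32.7% in this assay. Compound 2 `COc1ccc(Br)cc1Nc1cc(NC(=O)Nc2c(Cl)cccc2Cl)ncn1` gives 53.3%, and compound 3 `COc1ccc(Nc2cc(NC(=O)Nc3c(Cl)cccc3Cl)ncn2)cc1C` gives 45.1%. Among the measured compounds shown here, the one measured step between neighbours differing in a single place is a number 8.2 percentage points lower from compound 2 to compound 3 (within the scatter); an aryl swap on the nitrogen on the aromatic ring of the shared core therefore moves the read-out only within the scatter. On the numbers shown, compound 1 stands lowest of the three: its nearest neighbour is compound 3, a number higher by more than the scatter, and the furthest is compound 2, higher still.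

Compound 4 `CCc1cccc(Nc2cc(NC(=O)Nc3cc(OC)cc(OC)c3)ncn2)c1` is not yet measured. It differs from compound 1 by 3-ethylphenyl in place of 4-ethylphenyl on a nitrogen on an aromatic ring, the two having the same atoms joined differently. For the measured compounds named here, the only measured step that bears on this change is the aryl swap on the same nitrogen from compound 2 to compound 3, which stayed within the scatter, and that swap exchanged more than a single substituent position. Going by the values given here, no step of the ethylphenyl kind has been measured. A step of a number 2.3 percentage points higher from compound 1 to compound 4 (within the scatter) is therefore expected, that is, none beyond the scatter, in no firm direction. Compound 4 is estimated at 35%, with a range from 20% to 52%.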

Compound 4, a percentage reported as inhibition, at one concentration (the size of the read-out at that concentration, not a potency): 27.7%
Compound 4: the middle estimate sits 7.3 percentage points above what was measured; measured number inside the range.
By their numbers in this assay, from the lowest: compounds 4 and 1 (each within the scatter of the next); then compounds 3 and 2 (each within the scatter of the next).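

In this assay the ethyl group's change of position, 3-ethylphenyl in place of 4-ethylphenyl on a nitrogen on an aromatic ring, gives a number 5 percentage points lower from compound 1 to compound 4 (within the scatter), and this isolates a single change of attachment with the same atoms, which the broader aryl swap between compound 2 and compound 3 could not do. It also extends the reading to a second background: with the dimethoxyphenyl group of compound 1 in place of the dichlorophenyl group of compound 2 and compound 3, a change on this nitrogen again stays within the scatter, and neither measured pair goes against this. No measurement available here bears on why the ethyl position makes so little difference to this result.

On these data alone, whether a longer chain such as butyl, or an amine or a carboxylic acid, in place of ethyl on this phenyl ring would move the read-out beyond the scatter stays open. As far as these compounds go, what the dimethoxyphenyl group contributes on its own also stays open.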